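The compounds below may be only part of what the source reports. "The series", "measured", "known", "first", "only" and "open" are said of these compounds alone.

Compound 3 `COc1cc(OC)cc(-c2cn(-c3ccc(O)c(C(=O)Nc4cccc(C(F)(F)F)c4)c3)nn2)c1` gives the highest of the three numbers measured in a functional assay on CCRF-CEM cells (Homo sapiens) for inhibition, read by MTT assay, with a stated time of 2 days, tested at 10 uM; a lower number here means less inhibition, a higher number more inhibition at the concentration tested (going by the name of the read-out): compound 3 gives 73%, while compound 1 `COc1ccc(OC)c(-c2cn(-c3ccc(O)c(C(=O)Nc4cccc(C(F)(F)F)c4)c3)nn2)c1` gives 15% and compound 2 `COc1ccc(-c2cn(-c3ccc(O)c(C(=O)Nc4cccc(C(F)(F)F)c4)c3)nn2)cc1` gives 12%. The step of a number 58 percentage points higher from compound 1 to compound 3 (beyond the scatter) and the step of a number 61 percentage points higher from compound 2 to compound 3 (beyond the scatter) are both large, whereas the step of a number 3 percentage points lower from compound 1 to compound 2 (within the scatter) is within the scatter. Compound 4 `O=C(Nc1cccc(C(F)(F)F)c1)c1cc(-n2cc(-c3cccc(O)c3)nn2)ccc1O` differs from compound 3 at the same aromatic carbon: 3-hydroxyphenyl in place of 3,5-dimethoxyphenyl on an aromatic carbon. Going by the values given here, no measured step covers a hydroxyl on this phenyl, but the two large steps show that the pattern of groups on this ring decides most of the spread, and only the 3,5-dimethoxyphenyl of compound 3 reached the high value. Since compound 4 loses that pattern, the account expects compound 4 to fall back toward compounds 1 and 2, with an estimated step of a number 43 percentage points lower from compound 3 to compound 4 (beyond the scatter). Compound 4 is therefore estimated at 30% in this assay, within a range from 8% to 65%.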

Compound 4, a percentage reported as inhibition, at one concentration (the size of the read-out at that concentration, not a potency): 13%
Compound 4: the middle estimate sits 17 percentage points above what was measured, within the range that was stated.
By their numbers in this assay, from the lowest: compounds 2, 4 and 1 (each within the scatter of the next); then compound 3.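

Compound 4 shows that a single hydroxyl on this phenyl does not retain the high number of the 3,5-dimethoxyphenyl in this assay: the change gives a number 60 percentage points lower from compound 3 to compound 4 (beyond the scatter). Compound 4 instead lies with the other two low compounds, at a number 1 percentage points higher from compound 2 to compound 4 (within the scatter) and a number 2 percentage points lower from compound 1 to compound 4 (within the scatter), so among the four groups at this aromatic carbon, only the 3,5-dimethoxyphenyl of compound 3 stands apart. The compounds shown offer no independent measurement that explains this difference.

As far as these compounds go, compound 4 changes both the kind and the number of groups on this phenyl, so the separate contribution of each remains open. A 3-methoxyphenyl or a 3,5-dihydroxyphenyl at this carbon would separate the two, while a 3,5-dimethylphenyl would test whether the oxygen atoms matter at all.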